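Methoxy to methyl on the pendant aryl ring: the step repeated

The compounds below may be only part of what the source reports. "The series", "measured", "known", "first", "only" and "open" are said of these compounds alone.

Measured so far in an ADME assay on CCRF-CEM cells (Homo sapiens) for cytotoxicity, with a stated time of 72 h; a higher number here means a weaker inhibitor, a lower number a stronger inhibitor:
- compound 1 `COc1ccc(-c2nc3sc(Cc4ccc(Cl)cc4)nn3c2Br)cc1`, this assay 58000 nM
- compound 2 `Cc1ccc(-c2nc3sc(Cc4ccc(Cl)cc4)nn3c2Br)cc1`, this assay > 250000 nM, a limit of the assay and not a number
- compound 3 `COc1ccc(-c2nc3sc(Cc4ccc(Cl)cc4)nn3c2C=O)cc1`, this assay 3800 nM

Two changes have been made on the core of compound 1. The first, (methyl in place of methoxy on an aromatic carbon), gave an at least 4.3-fold higher number from compound 1 to compound 2 (0.63 log units; beyond the scatter); the size of that step is bounded only from one side, since compound 2 sits at the limit of > 250000 nM in this assay, at which 1 of the 3 values shown sits. The second, (formyl in place of bromo on an aromatic carbon), gave a 15-fold lower number from compound 1 to compound 3 (1.18 log units; beyond the scatter), so compound 3 gives the lowest number of the two values that are numbers.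

Compound 4 `Cc1ccc(-c2nc3sc(Cc4ccc(Cl)cc4)nn3c2C=O)cc1` has not been measured in this assay. It differs from compound 3 by methyl in place of methoxy on an aromatic carbon, the same change as from compound 1 to compound 2, on the same place; the cores of the two pairs differ by formyl in place of bromo on an aromatic carbon. Going by the values given here, only one earlier example of the change exists, and its size is a lower bound, so the expectation rests on a single bounded step. From compound 3 to compound 4 a step of a 5.3-fold higher number from compound 3 to compound 4 (0.72 log units; beyond the scatter) is expected, because compound 1 to compound 2 gave an at least 4.3-fold higher number from compound 1 to compound 2 (0.63 log units; beyond the scatter). Compound 4 is therefore estimated at 20000 nM in this assay, expected within 6000 nM to 80000 nM.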

Compound 4, half-maximal inhibitory concentration: 17000 nM
Compound 4: middle estimate off by 1.2-fold (0.07 log units), on the high side; the range from low to high includes it.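

In this assay, methyl in place of methoxy on the formyl-bearing core gave a 4.5-fold higher number from compound 3 to compound 4 (0.65 log units; beyond the scatter), and the direction matches that seen on the bromo-bearing core: the same change on two cores in this assay, an at least 4.3-fold higher number (0.63 log units; beyond the scatter) from compound 1 to compound 2 and a 4.5-fold higher number (0.65 log units; beyond the scatter) from compound 3 to compound 4; the limit leaves it open whether they differ

Formyl in place of bromo, read on the methyl-bearing pair, gave an at least 14-fold lower number from compound 2 to compound 4 (1.16 log units; beyond the scatter), again in the same direction as on the methoxy-bearing pair: the same change on two cores in this assay, a 15-fold lower number (1.18 log units; beyond the scatter) from compound 1 to compound 3 and an at least 14-fold lower number (1.16 log units; beyond the scatter) from compound 2 to compound 4; the limit leaves it open whether they differ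

Compound 2 gives > 250000 nM, a limit of the assay and not a number, so these two pairs show that each change kept its direction on a second core but do not show that its size carries over exactly, and two cores say nothing yet about any further core.

Going by these compounds, it remains open whether the methoxy to methyl step keeps its direction with a third group in place of bromo or formyl, such as a nitrile, an amine or a carboxylic acid. Also open, on these data alone, is how a hydroxyl group or a longer chain such as ethoxy would compare with methoxy and methyl at the same place on the six-membered aromatic ring.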